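Sulfamate series: pyridinylmethyl to bromobenzyl on the aniline nitrogen

A few compounds are considered here, and "the series" means these few. Any claim that something is new, unique, unknown or untested is made for them only; others in the source may bear on it.

Measured compounds:
compound 1 `NS(=O)(=O)Oc1ccc2c(c1)CN(C(=O)c1ccc(N3CCN(Cc4ccccc4)CC3)cc1)CC2` 1.93
compound 2 `CCN(Cc1ccccn1)c1ccc(C(=O)N2CCc3ccc(OS(N)(=O)=O)cc3C2)cc1` 1.93
compound 3 `NS(=O)(=O)Oc1ccc2c(c1)CN(C(=O)c1ccc(N3CCN(c4ncccn4)CC3)cc1)CC2` 1.93

Of the compounds shown here, three sharing the sulfamate-bearing core have been measured in a physicochemical assay for lipophilicity; a lower number here means a more polar compound, a higher number a more lipophilic compound. For the measured compounds named here, compound 1 gives 1.93 and compound 3 gives 1.93; the one single-point step between them, no change at the digits printed from compound 1 to compound 3 (within the scatter), is flat within the scatter. Compound 2, in which the aromatic amine carries an ethyl group and a (pyridin-2-yl)methyl group instead of a piperazine ring, gives 1.93 and so stands level with compound 1 and compound 3 at the digits printed.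

The next compound, compound 4 `CCN(Cc1cccc(Br)c1)c1ccc(C(=O)N2CCc3ccc(OS(N)(=O)=O)cc3C2)cc1`, differs from compound 2 in one place: 3-bromophenyl in place of pyridin-2-yl on a saturated chain carbon bound to a nitrogen on an aromatic ring. Going by the values given here, the only measured step, no change at the digits printed from compound 1 to compound 3 (within the scatter), exchanged one ring on a ring amine nitrogen for another and showed nothing beyond the scatter; it does not cover a change in which a ring with one hetero atom and one hydrogen-bond acceptor leaves and a carbon-only ring carrying bromine enters, so it gives no direct guide. On the structural change alone an upward step in this assay is expected, and the flat measured series argues for keeping the range wide.

Compound 4 is therefore expected to give 2.8, with a range of 2.1 to 3.5. The expected step is a number 0.87 log units higher from compound 2 to compound 4 (beyond the scatter).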

Compound 4, partition coefficient: 1.93
The estimate for compound 4 lay 0.87 log units above the measured number; the whole stated range lies above it.
By their numbers in this assay, from the lowest: compounds 1, 2, 3 and 4 (each within the scatter of the next).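

In this assay, 3-bromophenyl in place of pyridin-2-yl on a saturated chain carbon bound to a nitrogen on an aromatic ring gives no change at the digits printed from compound 2 to compound 4 (within the scatter) in this series. For the compounds shown here, the only earlier step, no change at the digits printed from compound 1 to compound 3 (within the scatter) for the series, concerned a ring on an amine nitrogen in a ring, so this result adds a second place in the molecule and a different kind of exchange: a ring with one hetero atom and one hydrogen-bond acceptor leaves, and a carbon-only ring carrying bromine enters, with no step beyond the scatter at either place. No supporting observation accounts for this result.

Going by these compounds, whether a carboxylic acid or a primary aliphatic amine on the benzyl ring would leave the number at this level remains open, as does the outcome for a longer chain such as butyl in place of ethyl on the same nitrogen. On these data alone, with only these two steps, it also remains open whether any exchange at these places moves the read-out beyond the scatter.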